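This account rests on a few compounds, and the source may have more. Where it says the series, first, only, none or still open, it means among the compounds named here.

Measured compounds in an assay on HEK293 cells for displacement of a labelled ligand from NPC1-like intracellular cholesterol transporter 1 (Homo sapiens); a lower number here means a stronger inhibitor, a higher number a weaker inhibitor:
- compound 1 `CCc1nn(CC)c(C2CCN(C(=O)CN3CN(c4ccccc4)C4(CCN(C(=O)c5ccc(C6CCCCC6)cc5)CC4)C3=O)CC2)c1C`: "not determined" (no result reported)
- compound 2 `CC(C)(C)c1ccc(C(=O)N2CCC3(CC2)C(=O)N(CC(=O)N2CCN(S(C)(=O)=O)CC2)CN3c2ccccc2)cc1`: 19000 nM
- compound 3 `CS(=O)(=O)N1CCN(C(=O)CN2CN(c3ccccc3)C3(CCN(C(=O)c4ccc(C5CCCCC5)cc4)CC3)C2=O)CC1`: 6300 nM

Compound 2 holds the highest of the two numbers in this assay; its nearest neighbour is compound 3, reached by a 3.0-fold lower number from compound 2 to compound 3 (0.48 log units; beyond the scatter), a change of cyclohexyl in place of tert-butyl on an aromatic carbon. Compound 1 carries no number and gives no bearing.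

Compound 4 `CC(C)(C)c1ccc(C(=O)N2CCC3(CC2)C(=O)N(CC(=O)NCCCCCO)CN3c2ccccc2)cc1` is the next compound to be measured in this assay. It differs from compound 2 by (5-hydroxypentyl)amino in place of 4-(methylsulfonyl)piperazin-1-yl on a carbonyl carbon. Within the data shown here, the only measured step, that from compound 2 to compound 3, concerns a different part of the molecule, the aromatic substituent, and does not touch the group on the carbonyl carbon that is changed here. Among the measured compounds shown here, no measured step therefore bears on this change, and no direction can be read from the series. The expectation for compound 4 is a number close to that of compound 2, with no change at the digits printed from compound 2 to compound 4 (within the scatter) expected to stay within the scatter. Compound 4 is thus estimated at 19000 nM, in a range from 6000 nM to 60000 nM.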

Compound 4, half-maximal inhibitory concentration: 9400 nM
Estimate against measurement, compound 4: 2.0-fold (0.31 log units) above, and the stated range covers the measured number.
By their numbers in this assay, from the lowest: compounds 3 and 4 (each within the scatter of the next); then compound 2.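

In this assay, the group on the carbonyl carbon now has a measured step of its own, which the aromatic substituent step could not supply: the exchange gives a 2.0-fold lower number from compound 2 to compound 4 (0.31 log units; beyond the scatter) and is modest in size. With the tert-butyl group held constant, the 4-(methylsulfonyl)piperazin-1-yl ring can therefore give way to a chain with no ring without any rise in the number. No available measurement ties this step to any one feature of the exchange, whether the ring that leaves or the hydrogen-bond donors that enter.

Still open, from the compounds shown here alone, is how an amine or a carboxylic acid in place of the hydroxy group, or a longer chain, would read at this position. Also open, going by these compounds, is whether (5-hydroxypentyl)amino gives a step of similar direction and size when cyclohexyl replaces tert-butyl.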